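The source may hold more compounds than are shown below. What is called first, only, known or untested is meant among the compounds shown, and "the series" means these compounds.

Measured so far in a toxicity assay on HepG2 2.2.15 cells (Homo sapiens) for cytotoxicity, read by CellTiter-Glo; on this read-out lower numbers stand for higher toxicity in this test and higher numbers for lower toxicity in this test:

compound 1 `O=C1NC(c2ccccc2)CN1c1cnn2c1CN(C(=O)Nc1cc(F)c(F)c(F)c1)C(C1CC1)C2` — 38500 nM
compound 3 `O=C1CC(c2cnc(C(F)(F)F)s2)CN1c1cnn2c1CN(C(=O)Nc1cc(F)c(F)c(F)c1)C(C1CC1)C2` — 38500 nM
compound 2 `C[C@H]1Cn2ncc(N3CC(c4ccccc4)CC3=O)c2CN1C(=O)NCc1cc(F)c(F)c(F)c1` — > 2000 nM, which is a limit of the assay and not a number.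

In this assay compound 1 and compound 3 stand at the same figure, within the usual scatter of each other, even though they carry different groups on the shared core. Compound 2 offers only a limit, (the limit of > 2000 nM in this assay, at which 1 of the 3 values shown sits), so it gives no foothold for comparison. Within the data shown here, no pair of measured compounds differs in just one place, so there is no measured step to lean on.

The unmeasured compound 4 `CC1(C)CC(=O)N(c2cnn3c2CN(C(=O)Nc2cc(F)c(F)c(F)c2)C(C2CC2)C3)C1` differs from compound 1 in one place: 4,4-dimethyl-2-oxopyrrolidin-1-yl in place of 2-oxo-4-phenylimidazolidin-1-yl on an aromatic carbon. Since compound 1 gives 38500 nM and compound 3 gives 38500 nM with different groups at that same place, the expectation is that this change makes no step beyond the scatter. The step from compound 1 to compound 4 is therefore expected to be about a 1.1-fold lower number from compound 1 to compound 4 (0.04 log units; within the scatter). Compound 4 is estimated at 35000 nM, with a likely range from 15000 nM to 80000 nM.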

Compound 4, half-maximal cytotoxic concentration: 115000 nM
The estimate for compound 4 lay 3.3-fold (0.52 log units) below the measured number; measured number outside the range, above it.
By their numbers in this assay, from the lowest: compounds 1 and 3 (each within the scatter of the next); then compound 4.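

Replacing 2-oxo-4-phenylimidazolidin-1-yl with 4,4-dimethyl-2-oxopyrrolidin-1-yl gives a 3.0-fold higher number from compound 1 to compound 4 (0.48 log units; beyond the scatter), a modest move toward lower toxicity in this assay. So the group on this aromatic carbon can shift the number, which the matching figures of compound 1 and compound 3 had not revealed. Nothing measured here explains the step.

This single change removes the six-membered aromatic ring and the hydrogen-bond donor together and leaves fewer heavy atoms, so the contribution of each remains unresolved. Also open, on these data alone, is how the same place would read in this assay with a plain 2-oxopyrrolidin-1-yl carrying no methyl groups, or with a small amine or a carboxylic acid on that carbon.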